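Trading a sulfonyl pyrrolidine for a triazolone azetidine

The compounds below may be only part of what the source reports. "The series", "measured", "known", "first", "only" and "open" are said of these compounds alone.

The measured compounds in an ADME assay on MT4 cells (Homo sapiens) for cytotoxicity, read by MTT assay, with a stated time of 5 days (on this read-out higher numbers stand for lower toxicity in this test and lower numbers for higher toxicity in this test), are:
Compound 1, `Cc1cc(C)cc(S(=O)(=O)c2c(C(=O)N[C@@H]3CCN(Cc4n[nH]c(=O)n4C)C3)[nH]c3ccc(Cl)cc23)c1`, which gives 22400 nM.
Compound 2, `Cc1cc(C)cc(S(=O)(=O)c2c(C(=O)N[C@@H]3CCN(S(C)(=O)=O)C3)[nH]c3ccc(Cl)cc23)c1`, which gives 24000 nM.
Compound 3, `Cc1cc(C)cc(S(=O)(=O)c2c(C(=O)N[C@H]3CCN(Cc4ccccc4C#N)C3)[nH]c3ccc(Cl)cc23)c1`, which reports only a limit of the assay, > 228000 nM.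

Compound 2 has the highest of the two numbers given; its nearest neighbour is compound 1, with a 1.1-fold higher number from compound 1 to compound 2 (0.03 log units; within the scatter), a group of 4 heavy atoms in place of a group of 8 heavy atoms on an amine nitrogen in a ring. Compound 3 stands at the limit noted as the limit of > 228000 nM in this assay, at which 1 of the 3 values shown sits.

Compound 4, `Cc1cc(C)cc(S(=O)(=O)c2c(C(=O)NC3CN(Cc4n[nH]c(=O)n4C)C3)[nH]c3ccc(Cl)cc23)c1`, has not yet been measured. Relative to compound 2 the change is a group of 12 heavy atoms (7 carbon, 4 nitrogen, 1 oxygen; one four-membered non-aromatic ring with 1 hetero atom, one five-membered aromatic ring with 3 hetero atoms) in place of a group of 9 heavy atoms (5 carbon, 1 nitrogen, 2 oxygen, 1 sulfur; one five-membered non-aromatic ring with 1 hetero atom), on an amide-type nitrogen. Among the measured compounds shown here, the only measured step, from compound 1 to compound 2, exchanges groups on the amine nitrogen in a ring and left the number within the scatter, while the present change sits on the amide-type nitrogen and replaces the whole ring; no measured step bears on it directly. Compound 4 carries the same five-membered aromatic ring with 3 hetero atoms as compound 1, whose value of 22400 nM is within the scatter of compound 2. Compound 4 is therefore expected to show a 1.0-fold higher number from compound 2 to compound 4 (0.02 log units; within the scatter), nothing beyond the scatter. The estimate for compound 4 in this assay is 25000 nM, in the range 10000 nM to 65000 nM.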

Compound 4, half-maximal cytotoxic concentration: 25200 nM
Compound 4: middle estimate off by 1.0-fold (0.00 log units), on the low side, within the range that was stated.
By their numbers in this assay, from the lowest: compounds 1, 2 and 4 (each within the scatter of the next). At a limit, above all of these: compound 3.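

In this assay the exchange on the amide-type nitrogen gives a 1.1-fold higher number from compound 2 to compound 4 (0.02 log units; within the scatter) and so stays inside the scatter, even though the whole 1-(methylsulfonyl)pyrrolidin-3-yl group leaves. Among the compounds shown here, the only earlier step sat on the amine nitrogen in a ring, so this is the first sign that a change at the amide-type nitrogen, bringing in a four-membered non-aromatic ring and a five-membered aromatic ring with 3 hetero atoms, can also leave the number unmoved. Nothing measured here gives a reason for this result.

As far as these compounds go, it remains open whether a carboxylic acid or a primary amine in place of the five-membered aromatic ring would also stay within the scatter. Compound 3 reports only a limit of the assay, and what sets it apart remains unresolved: the limit of > 228000 nM in this assay, at which 1 of the 4 values shown sits.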